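Swapping the Ring on the Benzyl-Like Arm of Compound 3

The source may hold more compounds than are shown below. What is called first, only, known or untested is meant among the compounds shown, and "the series" means these compounds.

Compound 1 `NCCCCCOC[C@H]1O[C@@H](OCCc2c[nH]c3ccccc23)[C@H](OCc2ccccc2)[C@@H](OCc2ccccc2)[C@@H]1OCc1cccnc1` gives 360 nM in an assay on isolated protein for binding affinity to somatostatin receptor type 4 (Homo sapiens), read by radioligand binding; on this read-out higher numbers stand for weaker inhibition and lower numbers for stronger inhibition.
Compound 2 `NCCCCCOC[C@H]1O[C@@H](OCCc2c[nH]c3ccccc23)[C@H](OCc2ccccc2)[C@@H](OCc2ccccc2)[C@@H]1OCc1ccncc1` gives 570 nM in this assay.
Compound 3 `NCCCCCOC[C@H]1O[C@@H](OCCc2c[nH]c3ccccc23)[C@H](OCc2ccccc2)[C@@H](OCc2ccccc2)[C@@H]1OCc1cnccn1` gives 260 nM in this assay.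

Among these three, compound 3 stands at the lowest number in this assay. Its nearest neighbour is compound 1, separated by a 1.4-fold lower number from compound 1 to compound 3 (0.14 log units; within the scatter), while the wider gap is a 2.2-fold lower number from compound 2 to compound 3 (0.34 log units; beyond the scatter).

Compound 4 `Cc1ccc(CO[C@H]2[C@H](OCc3ccccc3)[C@@H](OCc3ccccc3)[C@H](OCCc3c[nH]c4ccccc34)O[C@@H]2COCCCCCN)cn1` carries the change (6-methylpyridin-3-yl in place of pyrazin-2-yl on a saturated chain carbon bound to an oxygen on a saturated carbon). The earlier steps shown here that bear on it are the exchanges of one six-membered aromatic ring for another at the same place: a 1.4-fold lower number from compound 1 to compound 3 (0.14 log units; within the scatter) and a 1.6-fold higher number from compound 1 to compound 2 (0.20 log units; within the scatter), both small. Among the measured compounds shown here, compound 1 already holds pyridin-3-yl; compound 4 adds a methyl to that ring, and no measured step tells what a methyl does there. The expected step is therefore a 1.3-fold higher number from compound 3 to compound 4 (0.13 log units; within the scatter), a small move back toward the value of compound 1, not beyond the scatter. Compound 4 is estimated at 350 nM, with a range from 150 nM to 800 nM.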

Compound 4, inhibition constant: 1260 nM
The estimate for compound 4 lay 3.6-fold (0.56 log units) below the measured number; the measured number lies above the stated range.
By their numbers in this assay, from the lowest: compounds 3, 1 and 2 (each within the scatter of the next, the first and the last beyond it); then compound 4.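

In this assay, methyl in place of hydrogen on the aromatic ring of compound 1 gives a 3.5-fold higher number from compound 1 to compound 4 (0.54 log units; beyond the scatter), so one added carbon on the ring at this place can change the number beyond the scatter. The other two comparisons agree, with a 4.8-fold higher number from compound 3 to compound 4 (0.69 log units; beyond the scatter) and a 2.2-fold higher number from compound 2 to compound 4 (0.34 log units; beyond the scatter), which makes compound 4 the weakest of the four. The earlier ring exchanges alone did not show that this arm could lose this much from so small an addition.

Nothing available explains the loss seen with the methyl. On these data alone, it remains open whether the loss belongs to methyl alone or would also appear with ethyl, methoxy, chlorine or an amine on the same ring, and whether methyl would have the same effect on the pyrazin-2-yl ring.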